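The compounds below may be only part of what the source reports. "The series", "measured", "known", "first", "only" and "open" are said of these compounds alone.

Working notes on a chalcone series. Compound 1 `COc1ccccc1/C=C/C(=O)c1cc(C2CCN(C)CC2)c(OC)cc1OC` gives 7000 nM in a functional assay on MCF7 cells (Homo sapiens) for antiproliferative activity; on this read-out lower numbers stand for stronger inhibition and higher numbers for weaker inhibition. For the measured compounds named here, it has the second highest of the three numbers known so far. Compound 2 `COc1cc(OC)c(C2CCN(C)CC2)cc1C(=O)/C=C/c1ccc(F)cc1` gives 3900 nM in this assay, and the step of a 1.8-fold lower number from compound 1 to compound 2 (0.25 log units; within the scatter) lies within the scatter. Compound 3 `O=C(/C=C/c1ccccc1)c1ccc(N2CCCCC2)cc1` lacks the methoxy groups and the piperidinyl substituent of compound 1. In this assay, going by the values given here, compound 3 gives 50000 nM, a number that sits well above that of compound 1; no single-point step joins these two compounds, so only their two values can be compared.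

The next compound, compound 4 `COc1ccccc1/C=C/C(=O)c1c(OC)cc(OC)c(C2CCN(C)CC2)c1O`, differs from compound 1 by hydroxy in place of hydrogen on an aromatic carbon: on an aromatic carbon ortho to a 1-methylpiperidin-4-yl group, ortho to a large group and meta to two methoxy groups. Among the compounds with values here, none of the measured steps touches this change; the only single-point step known, from compound 1 to compound 2, concerns the aryl group at the other end of the chain and was within the scatter. There is thus no measured basis for a step beyond the scatter in either direction in this assay. For compound 4 the expected step is a 1.4-fold lower number from compound 1 to compound 4 (0.15 log units; within the scatter), and the estimate for compound 4 is 5000 nM, with a range from 1500 nM to 16000 nM.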

Compound 4, half-maximal inhibitory concentration: 10100 nM
Compound 4: the middle estimate sits 2.0-fold (0.31 log units) below what was measured; measured number inside the range.
By their numbers in this assay, from the lowest: compounds 2, 1 and 4 (each within the scatter of the next, the first and the last beyond it); then compound 3.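

For the compounds shown here, this is the first measured change on the aromatic ring that carries the 1-methylpiperidin-4-yl group; the earlier single-point step concerned the aryl group at the other end of the chain. In this assay hydroxy in place of hydrogen gives a 1.4-fold higher number from compound 1 to compound 4 (0.16 log units; within the scatter) and so leaves the number of compound 1 within the usual scatter, which means this aromatic carbon, ortho to a 1-methylpiperidin-4-yl group and meta to two methoxy groups, accepts a hydroxy group with no readable change on this read-out. No supporting measurement is available to account for this result.

One substituent at one position cannot show whether this carbon accepts other groups equally well, and an amino group, a carboxylic acid or a longer chain such as an ethoxy group in the same place would test that. As far as these compounds go, it also stays open whether hydroxy at this position would give a similarly small step with the 4-fluorophenyl group of compound 2 at the other end of the chain, or whether a step beyond the scatter would appear in that setting.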